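This account rests on a few compounds, and the source may have more. Where it says the series, first, only, none or still open, it means among the compounds named here.

Going by the values given here, compound 1 `FC(F)(F)c1cccc(NC(=S)Nc2ccc(Cl)cc2)c1` gives 11000 nM in an ADME assay on Vero 76 cells (Chlorocebus sabaeus) for cytotoxicity, read by crystal violet staining, with a stated time of 96 h (a lower number here means that less compound is tolerated, a higher number that more compound is tolerated), the second highest of the three numbers measured so far. Compound 3 `O=[N+]([O-])c1ccc(NC(=S)Nc2cccc(C(F)(F)F)c2)cc1` gives 10000 nM, and the step of a 1.1-fold lower number from compound 1 to compound 3 (0.04 log units; within the scatter) shows that the two are not distinguished by this assay. Compound 2 `CCOC(=O)c1ccc(NC(=S)Nc2cccc(C(F)(F)F)c2)cc1` gives 71000 nM; the step of a 6.5-fold higher number from compound 1 to compound 2 (0.81 log units; beyond the scatter) and the step of a 7.1-fold lower number from compound 2 to compound 3 (0.85 log units; beyond the scatter) both set compound 2 apart from the other two.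

Compound 4 `FC(F)(F)c1cccc(NC(=S)Nc2ccccc2Br)c1` differs from compound 1 in one place: 2-bromophenyl in place of 4-chlorophenyl on an amide-type nitrogen. The three measured steps all change a group on the 4-chlorophenyl that here leaves as a whole, so they bear only indirectly on this change. The step of a 1.1-fold lower number from compound 1 to compound 3 (0.04 log units; within the scatter) shows that exchanging chloro for nitro on that ring left the number within the scatter, while the step of a 6.5-fold higher number from compound 1 to compound 2 (0.81 log units; beyond the scatter) shows that ethoxycarbonyl raised it modestly. Among the compounds with values here, no measured step exchanges one halogen for another or moves a group around that ring, so there is no direct precedent. On the evidence of compound 1 and compound 3 he expects a step of a 1.1-fold higher number from compound 1 to compound 4 (0.04 log units; within the scatter) that stays within the scatter, with no clear direction. For compound 4 he therefore estimates 12000 nM, in the range 5000 nM to 30000 nM.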

Compound 4, half-maximal cytotoxic concentration: 50000 nM
Estimate against measurement, compound 4: 4.2-fold (0.62 log units) below, and the stated range ends below it.
By their numbers in this assay, from the lowest: compounds 3 and 1 (each within the scatter of the next); then compounds 4 and 2 (each within the scatter of the next).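

In this assay, putting 2-bromophenyl in place of 4-chlorophenyl on the amide-type nitrogen gives a 4.5-fold higher number from compound 1 to compound 4 (0.66 log units; beyond the scatter), so this change moves the number beyond the scatter although the two groups match in heavy atoms and in hydrogen-bond donors and acceptors. Among the earlier compounds, only the ethoxycarbonyl of compound 2 had set a number apart from compound 1, while the nitro of compound 3 had not; a ring bearing only a halogen now does so as well, and compound 4 at 50000 nM lies within the scatter of compound 2 at 71000 nM. No measurement given here accounts for this step.

The change alters both the halogen and its place on the ring at once, so the compounds shown do not tell which of the two goes with the step; 2-chlorophenyl and 4-bromophenyl on the same nitrogen are the groups that could separate them. Also open, from the compounds shown here alone, is how this number responds when the ring carries an amine, a carboxylic acid or a methoxy group instead of a halogen.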